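A few compounds are considered here, and "the series" means these few. Any claim that something is new, unique, unknown or untested is made for them only; others in the source may bear on it.

The measured compounds:
Compound 1 `CN(Cc1cccs1)C1CCN(CCCc2c[nH]c3ccc(-n4cnnc4)cc23)CC1` gives 4.3 nM in an assay on CHO cells for displacement of a labelled ligand from 5-hydroxytryptamine receptor 1D (Homo sapiens); on this read-out higher numbers stand for weaker inhibition and lower numbers for stronger inhibition.
Compound 2 `c1ccc(CNC2CCN(CCCc3c[nH]c4ccc(-n5cnnc5)cc34)CC2)cc1` gives 4.6 nM in this assay.
Compound 3 `c1ccc(NCC2CCN(CCCc3c[nH]c4ccc(-n5cnnc5)cc34)CC2)nc1` gives 1.7 nM in this assay.

Compound 1 stands second highest of the three numbers. Compound 2 lies within the scatter of it, whereas compound 3 sits lower, the step being a 2.5-fold lower number from compound 1 to compound 3 (0.40 log units; beyond the scatter). Compound 4 `CC(=O)Nc1ccc(CN(C)C2CCN(CCCc3c[nH]c4ccc(-n5cnnc5)cc34)CC2)cc1` differs from compound 1 in one place: 4-acetamidophenyl in place of thiophen-2-yl on a saturated chain carbon bound to an amine nitrogen. For the measured compounds named here, of the measured steps, the one from compound 1 to compound 2 bears most closely on this change, as it also replaces the (thiophen-2-yl)methyl group on the amine, while additionally removing the methyl on that nitrogen, and it gave a 1.1-fold higher number from compound 1 to compound 2 (0.03 log units; within the scatter). The steps of a 2.5-fold lower number from compound 1 to compound 3 (0.40 log units; beyond the scatter) and a 2.7-fold lower number from compound 2 to compound 3 (0.43 log units; beyond the scatter) alter the link between the saturated ring and the aryl group and so speak less directly to an aryl swap. Compound 4 is therefore expected to show a step of a 1.2-fold higher number from compound 1 to compound 4 (0.07 log units; within the scatter) in this assay, not beyond the scatter in either direction. The estimate for compound 4 is 5 nM, with a range from 1.5 nM to 16 nM.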

Compound 4, half-maximal inhibitory concentration: 19 nM
Beside the measured number, compound 4's estimate is 3.8-fold (0.58 log units) below it; the measured number lies above the stated range.
By their numbers in this assay, from the lowest: compound 3; then compounds 1 and 2 (each within the scatter of the next); then compound 4.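

In this assay, the aryl group on the saturated chain carbon bound to an amine nitrogen turns out not to be freely exchangeable: a 4.4-fold higher number from compound 1 to compound 4 (0.65 log units; beyond the scatter). The earlier 1.1-fold higher number from compound 1 to compound 2 (0.03 log units; within the scatter) had suggested tolerance for a change in this substituent, but 4-acetamidophenyl, which brings a hydrogen-bond donor and a double bond outside the aromatic ring, gives weaker inhibition than thiophen-2-yl, though the step is modest. No available evidence bears on what lies behind this step.

The compounds shown leave open whether the step belongs to the acetamido group or to the phenyl ring that carries it. A plain phenyl, an aminophenyl or a methoxyphenyl in the same place would help to separate these two readings.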